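The compounds below may be only part of what the source reports. "The series", "measured", "known", "first", "only" and "open" are said of these compounds alone.

Measured compounds in a functional assay on HeLa cells (Homo sapiens) for inhibition, read by MTT assay, with a stated time of 24 h; a higher number here means a weaker inhibitor, a lower number a stronger inhibitor:
- compound 1 `CCOC(=O)C1=Cc2ccccc2OC1(OCc1cn(CC(=O)Nc2ccc(C)cc2)nn1)C(F)(F)F`: 67400 nM
- compound 2 `CCCCCCCCn1cc(COC2(C(F)(F)F)Oc3ccccc3C=C2C(=O)OCC)nn1`: only a limit of the assay is recorded, > 150000 nM
- compound 3 `CCOC(=O)C1=Cc2ccccc2OC1(OCc1cn(-c2ccc(F)c(Cl)c2)nn1)C(F)(F)F`: 22700 nM

Compound 3 stands at the lowest of the two numbers recorded; its nearest neighbour is compound 1, and the two are separated by a 3.0-fold lower number from compound 1 to compound 3 (0.47 log units; beyond the scatter). Compound 2 sits at the limit (the limit of > 150000 nM in this assay, at which 1 of the 3 values shown sits), so its two steps are bounded only on one side: an at least 2.2-fold higher number from compound 1 to compound 2 (0.34 log units; beyond the scatter) and an at least 6.6-fold lower number from compound 2 to compound 3 (0.82 log units; beyond the scatter). All three measured steps change the group on the aromatic nitrogen of the five-membered ring; both steps that arrive at compound 3 replace a chain or a substituted chain with a six-membered aromatic ring, and both lower the number beyond the scatter.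

Compound 4 `CCOC(=O)C1=Cc2ccccc2OC1(OCc1cn(-c2ccc(C)cc2)nn1)C(F)(F)F` differs from compound 3 by 4-methylphenyl in place of 3-chloro-4-fluorophenyl on an aromatic nitrogen. This exchange keeps a six-membered aromatic ring on the aromatic nitrogen and alters only its substituents. For the measured compounds named here, none of the measured steps compares two such rings with one another, so no bearing on the direction exists beyond the observation that an aromatic ring at this position gave the lowest number so far. The expected step is therefore none beyond the scatter, a 1.3-fold higher number from compound 3 to compound 4 (0.12 log units; within the scatter). Compound 4 is estimated at 30000 nM in this assay, with a range from 10000 nM to 100000 nM.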

Compound 4, half-maximal inhibitory concentration: 25100 nM
Compound 4: middle estimate off by 1.2-fold (0.08 log units), on the high side; the measured number falls inside the stated range.
By their numbers in this assay, from the lowest: compounds 3 and 4 (each within the scatter of the next); then compound 1. At a limit, above all of these: compound 2.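

In this assay, for the compounds shown here, the first comparison of two six-membered aromatic rings on the aromatic nitrogen gives a 1.1-fold higher number from compound 3 to compound 4 (0.04 log units; within the scatter), so 4-methylphenyl and 3-chloro-4-fluorophenyl cannot be told apart at this position, and the series does not depend on the chlorine and fluorine of compound 3. The gain over the chain-type groups now rests on two different aromatic rings rather than one: a 2.7-fold lower number from compound 1 to compound 4 (0.43 log units; beyond the scatter) repeats with a second ring what compound 3 showed, and an at least 5.9-fold lower number from compound 2 to compound 4 (0.77 log units; beyond the scatter) does the same against the octyl group. Compound 2 is held only at a limit, so that last step is bounded on one side only: the limit of > 150000 nM in this assay, at which 1 of the 4 values shown sits.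

The compounds shown leave open whether any aromatic group on this nitrogen moves the number beyond the scatter of compounds 3 and 4, for instance a phenyl ring carrying an amine or a carboxylic acid, or a pyridine ring. From the compounds shown here alone, the ethyl ester and the trifluoromethyl group stay the same in all four compounds, so the effect of a carboxylic acid or an amide in place of that ester also remains open.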